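Fluoro on the hydroxyphenyl of a stilbene amidoxime

The compounds below may be only part of what the source reports. "The series", "measured", "known", "first", "only" and "open" are said of these compounds alone.

Compound 1 `N/C(=N\O)c1cccc(/C=C/c2ccc(O)c(-c3ccccn3)c2)c1`, > 50000 nM in an assay on isolated protein for inhibition of Amine oxidase [flavin-containing] A (Homo sapiens); a lower number here means a stronger inhibitor, a higher number a weaker inhibitor
Compound 2 `Nc1cccc(/C=C/c2ccc(O)c(-c3ccccn3)c2)c1`, > 50000 nM in this assay
Compound 3 `N/C(=N\O)c1cccc(/C=C/c2ccnc(-c3ccccc3O)c2)c1`, > 50000 nM in this assay

The three measured compounds share a stilbene backbone carrying an amidoxime or an amine on one ring and a hydroxyphenyl-pyridyl pair on the other. None of them gives a number in this assay: compound 1 is reported only as a limit, > 50000 nM. For compound 2 the result is likewise a limit, > 50000 nM. Compound 3 too sits at a limit, > 50000 nM. For the measured compounds named here, the one step between compounds differing in a single place, a step that the two limits leave unreadable from compound 1 to compound 2, therefore cannot be sized, and this follows from the limit of > 50000 nM in this assay, at which 3 of the 3 values shown sit.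

Compound 4 `N/C(=N\O)c1cccc(/C=C/c2ccnc(-c3cc(F)ccc3O)c2)c1` differs from compound 3 by fluoro in place of hydrogen on an aromatic carbon, which in the wider view turns 2-hydroxyphenyl into 5-fluoro-2-hydroxyphenyl. Going by the values given here, no measured step involves a change of this kind, and every value so far is a limit, so nothing on the numbers speaks for a change large enough to bring compound 4 within the range the assay reports. Compound 4 is therefore expected to remain at a limit, with a step from compound 3 estimated as a step that the limit leaves unreadable from compound 3 to compound 4, and an estimated value of 100000 nM, within 30000 nM to 300000 nM.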

Compound 4, half-maximal inhibitory concentration: > 50000 nM
Compound 4 gave a limit, no number (the forecaster's own chance of this, stated with the estimate: 85%); the middle value does not contradict the limit.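

The step between compound 3 and compound 4 cannot be read, as neither compound gives a number, only a limit: the limit of > 50000 nM in this assay, at which 4 of the 4 values shown sit. The compounds shown leave open whether fluoro in place of hydrogen has any effect on inhibition in this assay, and which change to the shared core, if any, would yield a measurable value.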